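This account rests on a few compounds, and the source may have more. Where it says the series, first, only, none or still open, it means among the compounds named here.

In a functional assay on KM12 cells (Homo sapiens) for inhibition, read by sulforhodamine B assay, with a stated time of 48 h (on this read-out higher numbers stand for weaker inhibition of growth and lower numbers for stronger inhibition of growth), the entry for compound 1 (`Cc1cn([C@H]2C[C@H](CC3=CC(=O)C(=O)C=C3)[C@@H](CO[Si](C)(C)C(C)(C)C)O2)c(=O)[nH]c1=O`) reads no result reported. Among the measured compounds shown here, compound 2 (`COc1ccc(C2([C@H]3C[C@H](n4cc(C)c(=O)[nH]c4=O)O[C@@H]3CO[Si](C)(C)C(C)(C)C)SCCCS2)cc1OC`) gives 4070 nM, the only number available, so there is nothing to rank it against. Compound 3 (`COc1ccc(C2([C@H]3C[C@@H](n4cc(C)c(=O)[nH]c4=O)O[C@@H]3CO[Si](C)(C)C(C)(C)C)SCCCS2)cc1OC`) has the same atoms and bonds as compound 2: the two compounds have the same atoms and bonds and differ only in configuration as drawn: 1 of 3 stereo elements differ; a stereocentre at a saturated ring carbon is drawn R in compound 2 and S in compound 3. A stereocentre at a saturated ring carbon is drawn R in compound 2 and S in compound 3, and no other feature changes. For the measured compounds named here, no measured pair in this small set shows what such an inversion does, so the data offer no guide to direction. The expectation in this assay is therefore a step that stays within the usual scatter, with neither direction favoured. The estimated change is a 1.1-fold higher number from compound 2 to compound 3 (0.04 log units; within the scatter). For compound 3 the expected value is 4500 nM, with an estimated range of 1800 nM to 12000 nM.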

Compound 3, concentration for 50% growth inhibition: 11000 nM
Beside the measured number, compound 3's estimate is 2.4-fold (0.39 log units) below it; measured number inside the range.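

In this assay, inverting the stereocentre at a saturated ring carbon from R to S gives a 2.7-fold higher number from compound 2 to compound 3 (0.43 log units; beyond the scatter). This shows that the number at this position responds to configuration alone, with the form drawn R giving the stronger inhibition of growth of the two. Among the compounds shown here, the earlier entries held a single number and no step, and the link between this shift and the inversion rests on one structural fact: the fact that compounds 2 and 3 differ only in the configuration as drawn.

The pair leaves open what inverting the remaining stereo elements would do, and whether this one inversion is specific to the substituents carried here. On these data alone, in particular, it remains unknown whether the gap between the two configurations would persist with a free hydroxyl in place of the silyl ether.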